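From Dimethylamino to 2-Aminoethoxy at the Assay Limit

The source may report more compounds than this note shows. Statements on the series, on what has been measured and on what is new or still open speak of the compounds shown alone.

In a functional assay on TOV21G cells (Homo sapiens) for antiproliferative activity, read by sulforhodamine B assay, with a stated time of 3 days (on this read-out higher numbers stand for weaker inhibition of growth and lower numbers for stronger inhibition of growth), compound 1 (`CCc1cc(F)ccc1-c1nc(-c2ccc3[nH]c(=O)oc3c2)cs1`) gives > 50000 nM, a limit and not a number. Compound 2 (`COc1cc(F)ccc1-c1nc(-c2ccc3[nH]c(=O)oc3c2)cs1`) gives > 50000 nM, also a limit. Compound 3 (`CN(C)Cc1cc(F)ccc1-c1nc(-c2ccc3[nH]c(=O)oc3c2)cs1`) gives > 50000 nM, again a limit. The series thus stands at the limit of > 50000 nM in this assay, at which 3 of the 3 values shown sit. Compound 4 (`NCCOCc1cc(F)ccc1-c1nc(-c2ccc3[nH]c(=O)oc3c2)cs1`) carries 2-aminoethoxy in place of dimethylamino on a saturated chain carbon bound to an aromatic carbon. The nearest measured changes are a step that the two limits leave unreadable from compound 1 to compound 3 and a step that the two limits leave unreadable from compound 2 to compound 3, so neither gives a size to carry over. No step beyond the scatter is expected in this assay, and the expected change is a number no higher from compound 3 to compound 4 (the limit leaves the size open). For compound 4 the estimated value is 50000 nM, with an expected range from 15000 nM to 100000 nM.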

Compound 4, concentration for 50% growth inhibition: > 50000 nM
Compound 4 was reported as a limit; the forecaster's own chance of this, stated with the estimate: 80%; the middle value sits exactly at the limit.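

In this assay compound 4 gives > 50000 nM, a limit and not a number. Among these compounds, no step between compound 4 and compound 1, compound 2 or compound 3 can be read. The compounds shown leave open whether any of these groups changes growth inhibition: the limit of > 50000 nM in this assay, at which 4 of the 4 values shown sit.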